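Compound 3 Enters the Cytotoxicity Series

This account rests on a few compounds, and the source may have more. Where it says the series, first, only, none or still open, it means among the compounds named here.

Of the compounds shown here, two of a shared core have been measured so far. In an ADME assay on cells (Macrophage, Homo sapiens) for cytotoxicity, read by MTT assay, with a stated time of 24 h (a higher number here means that more compound is tolerated, a lower number that less compound is tolerated), compound 1 `CC(O)Cn1c([N+](=O)[O-])cnc1/C=C/c1cccc(F)c1` gives 1030 nM, the highest of the two numbers. Compound 2 `CC(O)Cn1c([N+](=O)[O-])cnc1/C=C/c1cccc([N+](=O)[O-])c1` gives 430 nM in this assay, and the step of a 2.4-fold lower number from compound 1 to compound 2 (0.38 log units; beyond the scatter) is the only one recorded, a nitro in place of fluoro on an aromatic carbon.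

Compound 3 `CC(O)Cn1c([N+](=O)[O-])cnc1/C=C/c1ccccc1Br` has not yet been measured. It differs from compound 1 by 2-bromophenyl in place of 3-fluorophenyl on a double-bonded chain carbon bound to a double-bonded chain carbon. Among the measured compounds shown here, the one recorded step does not bear on this change: it swaps a fluoro for a nitro, while here one halogen replaces another and moves to a different position on the ring. For the measured compounds named here, there is thus no measured step that speaks directly to the exchange, and the account expects compound 3 to remain close to compound 1, with any shift in this assay of the size a 1.1-fold lower number from compound 1 to compound 3 (0.06 log units; within the scatter), which is expected to fall within the usual scatter. The estimate for compound 3 in this assay is 900 nM, expected between 400 nM and 2000 nM.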

Compound 3, half-maximal cytotoxic concentration: 490 nM
Compound 3: middle estimate off by 1.8-fold (0.26 log units), on the high side; low and high end bracket the measured number.
By their numbers in this assay, from the lowest: compounds 2 and 3 (each within the scatter of the next); then compound 1.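

In this assay the exchange of 3-fluorophenyl for 2-bromophenyl on a double-bonded chain carbon bound to a double-bonded chain carbon gives a 2.1-fold lower number from compound 1 to compound 3 (0.32 log units; beyond the scatter) and so shows that this place responds to a change that leaves the heavy-atom count, the six-membered aromatic ring and the absence of hydrogen-bond donors and acceptors as they were. Compound 1 now stands highest of the three, with its steps to both others beyond the scatter, while compound 2 and compound 3 lie within the scatter of each other even though their aromatic rings carry different groups. Nothing at hand accounts for the size or direction of the new step.

The compounds shown leave open how much of the step belongs to the change from fluorine to bromine and how much to the different place of the halogen on the ring, since both change together between compound 1 and compound 3. They also leave open how the number would respond to an amine or a carboxylic acid on the aromatic ring.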